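From 1-hydroxyethyl to hydroxymethyl in a small series

The source may report more compounds than this note shows. Statements on the series, on what has been measured and on what is new or still open speak of the compounds shown alone.

Measured so far:
compound 1 `CC[C@H](C)[C@H](NC(=O)CN(c1ncnc2c1ncn2C1CCCCO1)C1CC1)C(=O)OCc1ccccc1`: 27.4%
compound 2 `C[C@@H](O)[C@H](NC(=O)CN(c1ncnc2c1ncn2C1CCCCO1)C1CC1)C(=O)OCc1ccccc1`: 28.4%

Compound 2 gives 28.4% in a functional assay on the whole organism (Tail, strain ICR) with Mus musculus as the target, in the tail flick test, with a stated time of 60 min, at a dose of 25 umol/kg by the oral route (on this read-out lower numbers stand for a weaker effect and higher numbers for a stronger effect at the one dose given), the higher of the two numbers, but its nearest neighbour, compound 1, sits only a number 1 percentage points higher from compound 1 to compound 2 (within the scatter) away, so the two cannot be told apart. Compound 3 `O=C(CN(c1ncnc2c1ncn2C1CCCCO1)C1CC1)N[C@@H](CO)C(=O)OCc1ccccc1` differs from compound 2 by hydrogen in place of methyl on a saturated chain carbon bound to an oxygen on a saturated carbon and a saturated chain carbon. Among the measured compounds shown here, only one measured step exists in this small set, the exchange of ethyl for hydroxy from compound 1 to compound 2, and it moved the read-out by a number 1 percentage points higher from compound 1 to compound 2 (within the scatter), a change lost in the scatter. That step touches the same part of the molecule but is a different exchange, so it is an indirect guide at best; nothing here shows that a small change at this position shifts the read-out. Compound 3 is therefore expected to show a step of about a number 1.4 percentage points lower from compound 2 to compound 3 (within the scatter), no real change, giving an estimated 27% with a range from 15% to 40%.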

Compound 3, a percentage reported as activity, at one dose (the size of the read-out at that dose, not a potency): 46.7%
Compound 3: middle estimate off by 19.7 percentage points, on the low side, and the stated range ends below it.
By their numbers in this assay, from the lowest: compounds 1 and 2 (each within the scatter of the next); then compound 3.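

In this assay, the exchange of 1-hydroxyethyl for hydroxymethyl brings a number 18.3 percentage points higher from compound 2 to compound 3 (beyond the scatter) and shows that this position does respond to a very small change, which the earlier pair could not show. The exchange of sec-butyl for hydroxymethyl on the saturated chain carbon bound to an amide-type nitrogen and a carbonyl carbon brings a number 19.3 percentage points higher from compound 1 to compound 3 (beyond the scatter) as well, while compound 2 also carries a hydroxy group yet cannot be told apart from compound 1, so a hydroxy group alone does not go with the higher number. No measurement here gives a reason for the rise.

The compounds shown leave open whether the gain belongs to the hydroxymethyl group itself or simply to a shorter side chain. A plain methyl group, an aminomethyl group or a carboxylic acid on this carbon would help to separate these readings.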